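Chloro to hydrogen on the anilino ring of compound 1

The source may hold more compounds than are shown below. What is called first, only, known or untested is meant among the compounds shown, and "the series" means these compounds.

Measured so far, all in a functional assay on HepG2 cells (Homo sapiens) for antiproliferative activity, read by CCK-8 assay, with a stated time of 72 h, tested at 8 uM; on this read-out lower numbers stand for a weaker effect and higher numbers for a stronger effect at the one concentration tested:
- compound 1, `Nc1ccccc1NC(=O)/C=C/c1ccc(COCNc2nc(Nc3cccc(Cl)c3)c3ncn(C4CCCC4)c3n2)cc1`: 14.8%
- compound 2, `CC(C)n1cnc2c(Nc3cccc(Cl)c3)nc(NCOCc3ccc(/C=C/C(=O)Nc4ccccc4N)cc3)nc21`: 49.9%
- compound 3, `Nc1ccccc1NC(=O)c1ccc(COCNc2nc(Nc3cccc(Cl)c3)c3ncn(C4CCCC4)c3n2)cc1`: 63.2%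

Compound 1 stands lowest of the three numbers in this assay. Its nearest neighbour is compound 2, reached by a number 35.1 percentage points higher from compound 1 to compound 2 (beyond the scatter); the furthest is compound 3, reached by a number 48.4 percentage points higher from compound 1 to compound 3 (beyond the scatter). Both steps lie beyond the scatter and both go upward, so compound 1 is the weakest of the three on this read-out.

Compound 4, `Nc1ccccc1NC(=O)/C=C/c1ccc(COCNc2nc(Nc3ccccc3)c3ncn(C4CCCC4)c3n2)cc1`, differs from compound 1 in one place: hydrogen in place of chloro on an aromatic carbon. The (3-chlorophenyl)amino group becomes anilino; the cyclopentyl on the aromatic nitrogen and the 2-((2-aminophenyl)carbamoyl)ethenyl arm are kept.

Neither measured step bears on this change. The step to compound 2 alters the group on the aromatic nitrogen, the step to compound 3 alters the arm carrying the (2-aminophenyl)carbamoyl group; the anilino ring is untouched in both. There is thus no direct guide, only the observation that compound 1 sits low and that the two known changes elsewhere moved the number upward.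

Going by the values given here, with no bearing step, compound 4 is expected to stay near compound 1, the estimated step of a number 1.2 percentage points higher from compound 1 to compound 4 (within the scatter) lying within the scatter. The expected value for compound 4 in this assay is 16%, in a range from 2% to 38%.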

Compound 4, a percentage reported as inhibition, at one concentration (the size of the read-out at that concentration, not a potency): 18.8%
Compound 4: the middle estimate sits 2.8 percentage points below what was measured, and the stated range covers the measured number.
By their numbers in this assay, from the lowest: compounds 1 and 4 (each within the scatter of the next); then compound 2; then compound 3.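

In this assay the exchange of (3-chlorophenyl)amino for anilino gives a number 4 percentage points higher from compound 1 to compound 4 (within the scatter) and so does not separate the two compounds at the one concentration tested. Going by these compounds alone, this is the first reading at this position: on the background of the cyclopentyl and the 2-((2-aminophenyl)carbamoyl)ethenyl arm, the chloro on the aromatic carbon meta to a large group can give way to hydrogen without a step beyond the scatter, unlike the edits elsewhere, which give a number 35.1 percentage points higher from compound 1 to compound 2 (beyond the scatter) and a number 48.4 percentage points higher from compound 1 to compound 3 (beyond the scatter) on the same read-out. Nothing available explains this result.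

On these data alone, whether chloro and hydrogen also read alike with the isopropyl of compound 2 or the shorter (2-aminophenyl)carbamoyl arm of compound 3 remains open, since both of those compounds stand well above compound 1 and a difference at the ring might show there. Also open, as far as these compounds go, is how other groups at this place would read, for example fluoro, bromo, methoxy, an amine or a carboxylic acid, and whether any of them would move the number beyond the scatter.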